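Iodo Gives Way to 4-(tert-Butyl)phenyl in Compound 4

The compounds below may be only part of what the source reports. "The series", "measured", "known", "first", "only" and "open" are said of these compounds alone.

Measured compounds:
compound 1, `COc1cc2nc(N3CCN(S(=O)(=O)c4ccc(I)cc4)CC3)nc(N)c2cc1OC`, 15000 nM
compound 2, `COc1cc2nc(N3CCN(S(=O)(=O)c4ccc(Cl)s4)CC3)nc(N)c2cc1OC`, 25000 nM
compound 3, `COc1cc2nc(N3CCN(S(=O)(=O)c4cc(F)c(Cl)c(C(=O)O)c4)CC3)nc(N)c2cc1OC`, 56000 nM

In a functional assay on PC-3 cells (Homo sapiens) for inhibition (a lower number here means a stronger inhibitor, a higher number a weaker inhibitor), compound 1 gives the lowest of the three numbers. Its nearest neighbour is compound 2, and the step of a 1.7-fold higher number from compound 1 to compound 2 (0.22 log units; within the scatter) lies within the scatter, so no order between those two can be claimed. The step of a 3.7-fold higher number from compound 1 to compound 3 (0.57 log units; beyond the scatter) is beyond the scatter, and so is a 2.2-fold higher number from compound 2 to compound 3 (0.35 log units; beyond the scatter); all three compounds remain weak inhibitors in this assay.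

Compound 4, `COc1cc2nc(N3CCN(S(=O)(=O)c4ccc(-c5ccc(C(C)(C)C)cc5)cc4)CC3)nc(N)c2cc1OC`, is the next member. It differs from compound 1 in one place: 4-(tert-butyl)phenyl in place of iodo on an aromatic carbon. Going by the values given here, none of the measured steps exchanges a single substituent on the sulfonyl aryl for a larger aryl group, so no step bears directly on this change; the measured steps only show that the aryl group on the sulfonyl sulfur moves the number by a modest amount at most. Compound 4 is therefore expected to stay close to compound 1, with the step of no change at the digits printed from compound 1 to compound 4 (within the scatter) expected to fall within the scatter. The estimate for compound 4 in this assay is 15000 nM, between 5000 nM and 50000 nM.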

Compound 4, half-maximal inhibitory concentration: 10000 nM
For compound 4 the middle estimate is 1.5-fold (0.18 log units) above the measured one; the range from low to high includes it.
By their numbers in this assay, from the lowest: compounds 4, 1 and 2 (each within the scatter of the next, the first and the last beyond it); then compound 3.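

In this assay, 4-(tert-butyl)phenyl in place of iodo gives a 1.5-fold lower number from compound 1 to compound 4 (0.18 log units; within the scatter), so at this position, on an aromatic carbon para to a large group, a substituent of 10 heavy atoms with a six-membered aromatic ring of carbon only replaces a single iodine without a change that can be told from the scatter. The earlier steps shown here exchanged the whole group on the sulfonyl sulfur, whereas this one changes a single substituent on that aryl ring, and compound 4 remains a weak inhibitor at 10000 nM. No measurement of any other property bears on this result.

Going by these compounds, whether a primary amine or a morpholine ring in place of iodo would move the number beyond the scatter stays open. The compounds shown also leave open whether any group at this position can bring the number far below those seen so far.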